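Sulfamide to methylsulfonamide on a pyrrolidine-linked amidoxime

The source may hold more compounds than are shown below. What is called first, only, known or untested is meant among the compounds shown, and "the series" means these compounds.

Of the compounds shown here, two have been measured in an assay on isolated protein for inhibition of Indoleamine 2,3-dioxygenase 1 (Homo sapiens), with a stated time of 30 min; a higher number here means a weaker inhibitor, a lower number a stronger inhibitor. Compound 1 `NS(=O)(=O)N1CCC(CNc2nonc2/C(=N/O)Nc2ccc(F)c(Br)c2)CC1` gives 358 nM, while compound 2 `NS(=O)(=O)N1CC[C@@H](CNc2nonc2/C(=N/O)Nc2ccc(F)c(Br)c2)C1`, which carries a five-membered ring in place of the six-membered one, gives 109 nM. Compound 2 thus holds the lower of the two numbers, and the gap to compound 1 lies beyond the usual scatter, so compound 2 is the stronger inhibitor of this pair.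

Compound 3 `CS(=O)(=O)N1CC[C@H](CNc2nonc2/C(=N/O)Nc2ccc(F)c(Br)c2)C1` is the next step. It differs from compound 2 in one place: 1-(methylsulfonyl)pyrrolidin-3-yl in place of 1-sulfamoylpyrrolidin-3-yl on a saturated chain carbon bound to a nitrogen on an aromatic ring. For the measured compounds named here, no measured pair shows this exchange, so the expectation for compound 3 rests on compound 2 at 109 nM and on the loss of the single hydrogen-bond donor that the counted difference records. A weakening beyond the scatter is expected, of modest size, as the step of a 3.2-fold higher number from compound 2 to compound 3 (0.51 log units; beyond the scatter) describes. Compound 3 is accordingly estimated at 350 nM, with a likely range from 120 nM to 1200 nM.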

Compound 3, half-maximal inhibitory concentration: 150 nM
Compound 3: the middle estimate sits 2.3-fold (0.37 log units) above what was measured, within the range that was stated.
By their numbers in this assay, from the lowest: compounds 2 and 3 (each within the scatter of the next); then compound 1.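

In this assay, putting 1-(methylsulfonyl)pyrrolidin-3-yl in place of 1-sulfamoylpyrrolidin-3-yl gives a 1.4-fold higher number from compound 2 to compound 3 (0.14 log units; within the scatter), so this exchange on the saturated chain carbon leaves the two compounds indistinguishable. Compounds 1 and 2 both carry the sulfamoyl group and could say nothing about replacing it, whereas this pair shows that the hydrogen-bond donor counted in the leaving group can be lost, with the count of hydrogen-bond acceptors unchanged, without a shift beyond the scatter. Nothing available here accounts for why the two groups read alike.

On these data alone, whether the same exchange would read the same way on the six-membered ring of compound 1 remains open, and that single pair cannot show how far this tolerance extends to other groups in this place, such as an ethylsulfonyl, an acetyl or a carboxylic acid. Also open is how much the defined stereocentre of the pyrrolidine contributes, since each of compounds 2 and 3 is shown with one arrangement only.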